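The compounds below may be only part of what the source reports. "The series", "measured", "known", "first", "only" and "open" are said of these compounds alone.

In a functional assay on A-375 cells (Homo sapiens) for cytotoxicity, read by MTT assay, with a stated time of 72 h (a lower number here means a stronger inhibitor, a higher number a weaker inhibitor), the two measured compounds give:

Compound 1 `N/C(=N\NC(=S)N1CCOCC1)c1ccccn1`: 680 nM
Compound 2 `N/C(=N\NC(=S)N1CCSCC1)c1ccccn1`: 760 nM

Going by the values given here, compound 2 gives the highest of these two numbers, and its nearest neighbour is compound 1; the only step known, a 1.1-fold higher number from compound 1 to compound 2 (0.05 log units; within the scatter), lies within the scatter, so the two compounds cannot be told apart in this assay. Compound 3 `N/C(=N\NC(=S)N1CCCCC1)c1ccccn1` differs from compound 2 in one place: piperidin-1-yl in place of thiomorpholin-4-yl on a thiocarbonyl carbon. Among the compounds with values here, the one step that bears on this change is the one from compound 1 to compound 2, where a morpholin-4-yl was replaced by a thiomorpholin-4-yl on the same thiocarbonyl carbon, and that step was within the scatter. A second exchange at this position is therefore expected to leave this assay essentially unchanged, with a 1.0-fold lower number from compound 2 to compound 3 (0.01 log units; within the scatter) as the expected step. Compound 3 is estimated at 750 nM, with a range from 350 nM to 1600 nM.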

Compound 3, half-maximal inhibitory concentration: 680 nM
Compound 3: the middle estimate sits 1.1-fold (0.04 log units) above what was measured; the range from low to high includes it.
By their numbers in this assay, from the lowest: compounds 1, 3 and 2 (each within the scatter of the next).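

In this assay the exchange for piperidin-1-yl gives a 1.1-fold lower number from compound 2 to compound 3 (0.05 log units; within the scatter) and also no change at the digits printed from compound 1 to compound 3 (within the scatter). The earlier pair only swapped one ring hetero atom for another, whereas compound 3 has a six-membered ring with a single hetero atom, the nitrogen, and this leaves no change that the assay can detect. The three groups on this thiocarbonyl carbon therefore cannot be told apart here, and nothing available accounts for this.

From the compounds shown here alone, all three are six-membered rings, so it remains open whether the smaller pyrrolidin-1-yl ring, an open-chain dimethylamino group or a piperazin-1-yl ring with its free amine would also sit within the scatter. Changes elsewhere on the shared core also remain open.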